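The compounds below may be only part of what the source reports. "The series", "measured", "known", "first", "only" and "open" are said of these compounds alone.

In a functional assay on HeLa cells (Homo sapiens) for cytotoxicity, read by MTT assay, with a stated time of 2 days (a higher number here means a weaker inhibitor, a lower number a stronger inhibitor), compound 1 `Cc1ccc2nc(-c3ccccc3C(F)(F)F)[nH]c(=O)c2c1` gives 2450 nM, the highest of the three numbers measured and therefore the weakest inhibitor of the set. Compound 2 `O=c1[nH]c(-c2cccc3ccccc23)nc2ccc(N3CCCCC3)cc12` gives 330 nM and compound 3 `CCN(CC)c1ccc2nc(-c3cccc4ccccc34)[nH]c(=O)c2c1` gives 4 nM, so both lie well below compound 1 and beyond the scatter.

Compound 4 `Cc1ccc2nc(-c3ccccc3OC(F)(F)F)[nH]c(=O)c2c1` keeps the core of compound 1 and makes one change: trifluoromethoxy in place of trifluoromethyl on an aromatic carbon. In words, trifluoromethoxy stands in place of trifluoromethyl on an aromatic carbon.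

For the measured compounds named here, only one measured step links compounds that differ in one place, and it is large: an 83-fold lower number from compound 2 to compound 3 (1.92 log units; beyond the scatter). That step exchanges piperidin-1-yl for diethylamino, however, and leaves the trifluoromethyl group untouched, since neither compound carries it. It shows that a single exchange can move this assay strongly in this set, but it gives no direction for the present change. Going by the values given here, no measured pair tests trifluoromethoxy against trifluoromethyl.

With so little evidence, no shift beyond the scatter is expected, and the range is kept wide. The expected step is a 1.1-fold lower number from compound 1 to compound 4 (0.05 log units; within the scatter), with no firm direction. For compound 4 the estimated value is 2200 nM, with an expected range from 700 nM to 7000 nM.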

Compound 4, half-maximal inhibitory concentration: 850 nM
Compound 4: middle estimate off by 2.6-fold (0.41 log units), on the high side; the range from low to high includes it.
By their numbers in this assay, from the lowest: compound 3; then compound 2; then compound 4; then compound 1.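

For the compounds shown here, the step of a 2.9-fold lower number from compound 1 to compound 4 (0.46 log units; beyond the scatter) in this assay gives the first direct reading at this position, on an aromatic carbon of a six-membered aromatic ring of carbon only, ortho to a large group. Going by these compounds alone, it shows that trifluoromethoxy in place of trifluoromethyl gives a modest change that lies beyond the scatter, and that this exchange favours the lower number in this pair, which the earlier compounds could not show because none of them tested it. The exchange adds one oxygen and one hydrogen-bond acceptor and leaves the net charge unchanged, but no measurement here connects either difference with the step, and nothing measured on the two groups accounts for the shift.

The compounds shown leave open how other groups at this position would compare, such as a simple methoxy, a chlorine atom, an amine or a carboxylic acid. They also leave open whether trifluoromethoxy in place of trifluoromethyl would give a step of similar size and the same direction if the methyl group on the core were replaced by diethylamino or piperidin-1-yl.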